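Aryl swap on the shared core: from compound 2 to compound 3

The compounds below may be only part of what the source reports. "The series", "measured", "known", "first", "only" and "open" are said of these compounds alone.

Compound 1 `Cc1ccc(C2=NN(c3ccc(S(C)(=O)=O)cc3)C(=O)CC2)cc1`: 410 nM
Compound 2 `Cc1cc(O)ccc1C1=NN(c2ccc(S(C)(=O)=O)cc2)C(=O)CC1`: 5490 nM

In a functional assay on SK-MEL-5 cells (Homo sapiens) for inhibition, read by sulforhodamine B assay, with a stated time of 48 h (a lower number here means a stronger inhibitor of growth, a higher number a weaker inhibitor of growth), compound 2 stands at 5490 nM, the higher of the two numbers and so the weaker growth inhibitor of this pair. Compound 3 `CCc1ccc(C2=NN(c3ccc(S(C)(=O)=O)cc3)C(=O)CC2)cc1` has not yet been measured. It carries 4-ethylphenyl in place of the 4-hydroxy-2-methylphenyl of compound 2, on a carbon with a double bond to nitrogen: 4-ethylphenyl in place of 4-hydroxy-2-methylphenyl on a carbon with a double bond to nitrogen.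

Among the compounds with values here, one measured step bears on this change: a 13-fold higher number from compound 1 to compound 2 (1.13 log units; beyond the scatter), which is large and beyond the scatter. That step put 4-hydroxy-2-methylphenyl in place of 4-methylphenyl, and compound 3 again lacks the hydroxy group and returns to a single 4-substituted phenyl. Within the data shown here, no measured step covers 4-ethylphenyl in place of 4-methylphenyl, so compound 1, at 410 nM, is only an approximate guide. A large step to a lower number in this assay is therefore expected, of a size similar to the one above: an 11-fold lower number from compound 2 to compound 3 (1.04 log units; beyond the scatter). For compound 3 the estimated value is 500 nM, with an expected range of 150 nM to 1600 nM.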

Compound 3, concentration for 50% growth inhibition: 1480 nM
Compound 3: the middle estimate sits 3.0-fold (0.47 log units) below what was measured; the range from low to high includes it.
By their numbers in this assay, from the lowest: compound 1; then compound 3; then compound 2.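

In this assay the 4-ethylphenyl group recovers part of what the 4-hydroxy-2-methylphenyl group loses (a 3.7-fold lower number from compound 2 to compound 3 (0.57 log units; beyond the scatter)), yet compound 3 does not return to the level of compound 1, which has the lowest number of the three, with its steps to both others beyond the scatter. Within the data shown here, the new information lies in the comparison of the two groups without a hydroxy group: methyl in place of hydrogen on the saturated chain carbon bound to an aromatic carbon is enough to move the number (a 3.6-fold higher number from compound 1 to compound 3 (0.56 log units; beyond the scatter)), so this position on the carbon with a double bond to nitrogen responds to a small change in the chain as well as to the larger swap of a 13-fold higher number from compound 1 to compound 2 (1.13 log units; beyond the scatter), and the hydroxy-bearing group is not the only change that costs growth inhibition. Nothing at hand gives a reason for either step.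

Three compounds cannot show whether the number keeps rising along a longer chain such as propyl, or whether a branched isopropyl group behaves like the ethyl group. Compound 2 also changes two things on the ring at once, so the share of the hydroxy group stays unresolved, as does the effect of an amine or a methoxy group in its place.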